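Cyclobutyl in Place of Trifluoromethyl on a Shared Core

A few compounds are considered here, and "the series" means these few. Any claim that something is new, unique, unknown or untested is made for them only; others in the source may bear on it.

Compound 1 `C[C@H](NC(=O)c1c(C(F)(F)F)nnn1Cc1ccc(C(F)(F)F)cc1)c1ccc(C(=O)O)cc1` is one of two compounds tested in a functional assay on CHO cells for antagonist activity at prostaglandin E2 receptor EP4 subtype (Homo sapiens), read by calcium flux, with a stated time of 15 min (on this read-out lower numbers stand for stronger inhibition and higher numbers for weaker inhibition), and in this assay compound 1 gives 225 nM. Compound 2 `C[C@H](NC(=O)c1c(C(F)(F)F)nnn1CCOc1ccc(F)cc1)c1ccc(C(=O)O)cc1` differs by (4-fluorophenoxy)methyl in place of 4-(trifluoromethyl)phenyl on a saturated chain carbon bound to an aromatic nitrogen, and compound 2 gives 276 nM; the step of a 1.2-fold higher number from compound 1 to compound 2 (0.09 log units; within the scatter) is within the scatter, so the two numbers cannot be told apart. Compound 3 `C[C@H](NC(=O)c1c(C2CCC2)nnn1Cc1ccc(C(F)(F)F)cc1)c1ccc(C(=O)O)cc1` differs from compound 1 by cyclobutyl in place of trifluoromethyl on an aromatic carbon. For the measured compounds named here, no measured step touches this position, and the single step from compound 1 to compound 2 changes a different part of the molecule without a shift beyond the scatter, so it offers no direct guide. He therefore expects only a modest step for compound 3, with its direction uncertain, estimating a 1.8-fold higher number from compound 1 to compound 3 (0.25 log units; within the scatter). For compound 3 the estimate is 400 nM, expected to lie between 100 nM and 1600 nM.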

Compound 3, half-maximal inhibitory concentration: 75.3 nM
Estimate against measurement, compound 3: 5.3-fold (0.73 log units) above; measured number below the stated range.
By their numbers in this assay, from the lowest: compound 3; then compounds 1 and 2 (each within the scatter of the next).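

In this assay the change to cyclobutyl gives a 3.0-fold lower number from compound 1 to compound 3 (0.48 log units; beyond the scatter) and is the first step among these compounds to lie beyond the scatter. It shows that the number responds to the group on this aromatic carbon next to the ring nitrogen, which the earlier pair, both carrying trifluoromethyl there, could not show. The leaving and entering groups have the same count of heavy atoms and no hydrogen-bond donors or acceptors, so those counts do not separate them, and nothing measured here accounts for the lower number.

The compounds shown place only trifluoromethyl and cyclobutyl at this position, so it remains open how cyclopropyl, a longer chain or an amine would read there. On these data alone, it also remains open whether cyclobutyl would give a similar step alongside the 4-fluorophenoxy group of compound 2.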